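This account rests on a few compounds, and the source may have more. Where it says the series, first, only, none or still open, it means among the compounds named here.

Three compounds from one series have been run through a toxicity assay on HFF-1 cells (Homo sapiens) for cytotoxicity, read by WST assay, with a stated time of 72 h; on this read-out higher numbers stand for weaker inhibition and lower numbers for stronger inhibition. Compound 3, `CCN(CC)CC#CCSc1nc2c(c(=O)[nH]c(=O)n2C)n1C`, is the starting point of this account. In this assay compound 3 gives 3680 nM, the highest number of the three. Compound 1, `Cn1c(SCC#CCN2CCCC2)nc2nc(Cl)nc(SCC#CCN3CCCC3)c21`, gives 3630 nM, which lies within the scatter of the figure for compound 3, so the two cannot be told apart on this assay. Compound 2, `CCN(CC)CC#CCSc1nc(Cl)nc2nc(SCC#CCN(CC)CC)n(C)c12`, gives 1000 nM, a number beyond the scatter below that of compound 3; compound 2 differs from compound 1 at two places at once, so what separates their figures cannot be assigned to one of them.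

Compound 4, `Cn1c(SCC#CCN2CCCCC2)nc2c1c(=O)[nH]c(=O)n2C`, is not yet measured. It differs from compound 3 in one place: piperidin-1-yl in place of diethylamino on a saturated chain carbon bound to a triple-bonded carbon. For the measured compounds named here, no measured pair shows this exchange on its own, so there is no step to lean on. Given that compound 1 gives 3630 nM and compound 3 gives 3680 nM, both weak, the account expects compound 4 to stay weak and the step from compound 3 to compound 4 to be small, at most a slight rise in number, estimated as a 1.1-fold higher number from compound 3 to compound 4 (0.06 log units; within the scatter). For compound 4 the estimate is 4200 nM, with a range from 1500 nM to 12000 nM.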

Compound 4, half-maximal inhibitory concentration: 30400 nM
Compound 4: middle estimate off by 7.2-fold (0.86 log units), on the low side; measured number above the stated range.
By their numbers in this assay, from the lowest: compound 2; then compounds 1 and 3 (each within the scatter of the next); then compound 4.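

In this assay, for the compounds shown here, putting piperidin-1-yl in place of diethylamino on a saturated chain carbon bound to a triple-bonded carbon comes with an 8.3-fold higher number from compound 3 to compound 4 (0.92 log units; beyond the scatter), and this is the first step that can be read as a single change. It shows that this position is not indifferent: with the rest of compound 4 the same as compound 3, the amine at the end of the chain alone moves the number beyond the scatter, even though both groups have the same counts of hydrogen-bond donors and acceptors and neither has a net charge. Nothing on hand accounts for this step.

One pair cannot separate the effect of closing the ring from that of the added carbon, and it does not show whether the same exchange would move the number on the core of compound 1. Nor does it show where other amines at this position, such as dimethylamino or morpholin-4-yl, would fall on the core of compound 3.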